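The source may report more compounds than this note shows. Statements on the series, on what has been measured and on what is new or still open speak of the compounds shown alone.

Compound 1 `CS(=O)(=O)c1ccc(-n2c(=O)n(Cc3cc4cc(Cl)ccc4n3CCCC#N)c3cnccc32)cc1` carries a 4-(methylsulfonyl)phenyl group on an aromatic nitrogen of its core. In an ADME assay on HeLa cells (Homo sapiens) for cytotoxicity, read by ATP content, with a stated time of 3 days (a lower number here means that less compound is tolerated, a higher number that more compound is tolerated), compound 1 gives > 50000 nM, which is a limit of the assay rather than a number. Compound 2 `O=c1n(Cc2cc3cnccc3n2CCCCF)c2cnccc2n1C1CC1` gives > 50000 nM in this assay, also a limit. Compound 3 `CC1(n2c(=O)n(Cc3cc4cc(Cl)ccc4n3CCCS(C)(=O)=O)c3cnccc32)CC1` gives > 50000 nM in this assay, a limit as well. All three values therefore sit at the limit of > 50000 nM in this assay, at which 3 of the 3 values shown sit. Compound 4 `COc1ccc(-n2c(=O)n(Cc3cc4cc(Cl)ccc4n3CCCC#N)c3cnccc32)cc1C` has not yet been measured; it differs from compound 1 by 4-methoxy-3-methylphenyl in place of 4-(methylsulfonyl)phenyl on an aromatic nitrogen. Among the compounds with values here, no step between measured compounds is available to gauge this change, so no shift beyond the usual scatter is expected, and compound 4 is expected to remain at the same limit. The expected step is a step that the limit leaves unreadable from compound 1 to compound 4, essentially none. The estimate for compound 4 in this assay is 60000 nM, within 30000 nM to 120000 nM.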

Compound 4, half-maximal cytotoxic concentration: > 50000 nM
Compound 4 was reported as a limit (the forecaster's own chance of this, stated with the estimate: 85%); the middle value lies beyond the limit too.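

Compound 1 and compound 4 both stand at a limit, so no step can be read between them: the limit of > 50000 nM in this assay, at which 4 of the 4 values shown sit.

The compounds shown leave open what concentration of any of them would actually reach the half-maximal cytotoxic level in this assay.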